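A few compounds are considered here, and "the series" means these few. Any claim that something is new, unique, unknown or untested is made for them only; others in the source may bear on it.

Of the compounds shown here, three on a shared core have so far been measured in a functional assay on L1210 cells (Mus musculus) for inhibition (a higher number here means a weaker inhibitor, a lower number a stronger inhibitor), and differ only in the chain on a saturated ring carbon. Compound 1 `CCCCCCC[C@@]1(C)O[C@@H]2OC(=O)N(C(=O)CCl)[C@@H]2CC1=O` carries heptyl and gives (28000 nM). Compound 2 `CCCCCC#C[C@@]1(C)O[C@@H]2OC(=O)N(C(=O)CCl)[C@@H]2CC1=O` carries hept-1-yn-1-yl and gives (31000 nM). Compound 3 `CCCCC/C=C/[C@@]1(C)O[C@@H]2OC(=O)N(C(=O)CCl)[C@@H]2CC1=O` carries hept-1-en-1-yl and gives (81000 nM), the highest number of the three and so the weakest inhibitor here.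

In compound 4 `CCCCCC1OC1[C@@]1(C)O[C@@H]2OC(=O)N(C(=O)CCl)[C@@H]2CC1=O` 3-pentyloxiran-2-yl replaces hept-1-en-1-yl at that same carbon (3-pentyloxiran-2-yl in place of hept-1-en-1-yl on a saturated ring carbon).

Going by the values given here, the only guides are the earlier changes to this chain. One was within the scatter (a 1.1-fold higher number from compound 1 to compound 2 (0.04 log units; within the scatter)), and two were modest (a 2.9-fold higher number from compound 1 to compound 3 (0.46 log units; beyond the scatter)) and (a 2.6-fold higher number from compound 2 to compound 3 (0.42 log units; beyond the scatter)). Among the compounds with values here, no compound with this new group has been measured, so the direction is uncertain. A modest move to a lower number is expected, as an estimated step (a 2.0-fold lower number from compound 3 to compound 4 (0.31 log units; beyond the scatter)). For compound 4 the estimated value is 40000 nM within an expected range from 14000 nM to 110000 nM in this assay as well.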

Compound 4, half-maximal inhibitory concentration: 193000 nM
Compound 4: middle estimate off by 4.8-fold (0.68 log units), on the low side, outside the stated range (above it).
By their numbers in this assay, from the lowest: compounds 1 and 2 (each within the scatter of the next); then compound 3; then compound 4.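

In this assay, replacing hept-1-en-1-yl with 3-pentyloxiran-2-yl gives a further rise (a 2.4-fold higher number from compound 3 to compound 4 (0.38 log units; beyond the scatter)), so this change on the saturated ring carbon weakens inhibition rather than restoring it. The gap is wider against the other two chains (a 6.2-fold higher number from compound 2 to compound 4 (0.79 log units; beyond the scatter); a 6.9-fold higher number from compound 1 to compound 4 (0.84 log units; beyond the scatter)), which makes compound 4 the weakest inhibitor of the four and extends the spread seen at this carbon beyond what compounds 1, 2 and 3 showed. Nothing measured on these compounds accounts for the rise.

From the compounds shown here alone, it remains open whether the higher number goes with the three-membered ring itself or with its oxygen, a question that a cyclopropane ring carrying the same pentyl chain could address. Also open, going by these compounds, is whether a hydroxyl group on the heptyl chain, or a shorter chain, would shift the number at this carbon.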